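The source may hold more compounds than are shown below. What is called first, only, known or untested is meant among the compounds shown, and "the series" means these compounds.

Working notes on the series. Compound 3 `COc1cccc(/C=C2\CCC/C(=C\c3cccc([N+](=O)[O-])c3)C2=O)c1` gives 13.2 ug/mL in a functional assay on MDA-MB-231 cells (Homo sapiens) for cytotoxicity, read by MTT assay (a higher number here means a weaker inhibitor, a lower number a stronger inhibitor), the second highest of the three numbers in hand. Among the measured compounds shown here, compound 2 `COc1ccc(/C=C2\CCC/C(=C\c3cccc([N+](=O)[O-])c3)C2=O)cc1` gives 44.7 ug/mL, and the one measured step, a 3.4-fold lower number from compound 2 to compound 3 (0.53 log units; beyond the scatter), separates the two. For the measured compounds named here, compound 1 `CCCOc1c(Br)cc(/C=C2\CCC/C(=C\c3ccccc3[N+](=O)[O-])C2=O)cc1OC` gives 1.99 ug/mL, lower than compound 3, but differs from it in several places, so no single step connects them. Compound 4 `COc1cccc(/C=C2\CCC/C(=C\c3cccc([N+](=O)[O-])c3)C2=O)c1OC` carries methoxy in place of hydrogen on an aromatic carbon. Going by the values given here, no measured step adds a methoxy group to a ring that already holds one; the only step in hand moves a methoxy rather than adds one, so it bears on this change only loosely. The expected step is a 1.3-fold lower number from compound 3 to compound 4 (0.12 log units; within the scatter), essentially none beyond the scatter. For compound 4 the estimate is 10 ug/mL, ranging from 4 ug/mL to 30 ug/mL.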

Compound 4, half-maximal inhibitory concentration: 5.59 ug/mL
Estimate against measurement, compound 4: 1.8-fold (0.25 log units) above; measured number inside the range.
By their numbers in this assay, from the lowest: compound 1; then compound 4; then compound 3; then compound 2.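

In this assay the added methoxy, in place of hydrogen on an aromatic carbon, ortho to a large group and ortho to a methoxy group, gives a 2.4-fold lower number from compound 3 to compound 4 (0.37 log units; beyond the scatter) as its outcome. Among the compounds shown here, the earlier step only moved a methoxy, so this pair is the first to show that adding one at this position changes the number beyond the scatter. Nothing in hand bears on what lies behind this step. From the compounds shown here alone, whether a hydroxyl or an ethoxy group at this position gives a similar number stays open. So does whether the same addition has a similar effect in compound 2 or compound 1.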